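This account rests on a few compounds, and the source may have more. Where it says the series, first, only, none or still open, it means among the compounds named here.

Two chalcone-type compounds carrying a triazolylmethoxy side chain have been measured in a functional assay on MCF7 cells (Homo sapiens) for inhibition, read by MTT assay, with a stated time of 48 h, tested at 10 uM; on this read-out lower numbers stand for less inhibition of growth and higher numbers for more inhibition of growth at the one concentration tested. Compound 1 `COc1ccc(C(=O)/C=C/c2ccc(OCc3cn(Cc4ccc(Br)cc4)nn3)cc2)cc1` gives 53% in this assay. Compound 2 `O=C(/C=C/c1ccc(OCc2cn(Cc3ccccc3Br)nn2)cc1)c1ccc([N+](=O)[O-])cc1`, which bears a nitrophenyl ketone and a 2-bromobenzyl group on the triazole nitrogen, gives 43% in this assay. The two numbers lie within the usual scatter of each other, so neither compound is set apart from the other on this read-out; compound 2 simply provides the second of the two reference points. Compound 1 and compound 2 differ in more than one place, so the pair cannot be read as a single step.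

Compound 3 `O=C(/C=C/c1ccc(OCc2cn(Cc3ccc(Br)cc3)nn2)cc1)c1ccc([N+](=O)[O-])cc1` has not yet been measured in this assay. It differs from compound 2 in one place: 4-bromophenyl in place of 2-bromophenyl on a saturated chain carbon bound to an aromatic nitrogen. Within the data shown here, both compounds measured so far sit in the same band regardless of where the bromine stands on the benzyl ring, so for compound 3 the step of a number 5 percentage points higher from compound 2 to compound 3 (within the scatter) is expected to be small and to stay within the scatter, in no particular direction. Compound 3 is therefore estimated to give 48% in this assay, in the range 30% to 65%.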

Compound 3, percent growth inhibition at one concentration: 18%
The estimate for compound 3 lay 30 percentage points above the measured number; the measured number lies below the stated range.
By their numbers in this assay, from the lowest: compound 3; then compounds 2 and 1 (each within the scatter of the next).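

In this assay, the place of the bromine on the benzyl group proves not to be a neutral detail: 4-bromophenyl in place of 2-bromophenyl on a saturated chain carbon bound to an aromatic nitrogen gives a number 25 percentage points lower from compound 2 to compound 3 (beyond the scatter), although the two compounds have the same atoms, joined differently. With the 4-bromobenzyl group held constant, the other end of the molecule also matters, as nitro in place of methoxy on an aromatic carbon gives a number 35 percentage points lower from compound 1 to compound 3 (beyond the scatter), the larger of the two steps. Nothing measured on these compounds explains either step.

Each change is seen only once, against a single partner, so the compounds shown do not tell whether the bromine step would hold with methoxy in place of nitro, or whether the nitro step would hold with the 2-bromobenzyl group. They also leave open what an unsubstituted benzyl group, a chlorine in place of the bromine, or an amine in place of the nitro would give on the same core.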